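Series notes: aryl-piperazine oxazole amides, HL-60 growth

This account rests on a few compounds, and the source may have more. Where it says the series, first, only, none or still open, it means among the compounds named here.

Measured so far:
Compound 1 `COc1cc(OC)cc(N2CCN(C(=O)c3oc(C)nc3-c3cccc(F)c3)CC2)c1`; in a functional assay on HL-60 cells (Homo sapiens) for inhibition, read by MTT assay, with a stated time of 72 h (a higher number here means a weaker inhibitor, a lower number a stronger inhibitor), compound 1 gives 28.2 nM.
Compound 2 `Cc1ccc(N2CCN(C(=O)c3oc(C)nc3-c3ccccc3)CC2)c(C)c1`; in this assay compound 2 gives 101 nM.
Compound 3 `COc1cc(OC)cc(N2CCN(C(=O)c3oc(C)nc3-c3ccccc3F)CC2)c1`; in this assay compound 3 gives 10.3 nM.

Going by the values given here, compound 1 stands second highest of the three numbers in this assay: its nearest neighbour is compound 3, and the only single-point step recorded, a 2.7-fold lower number from compound 1 to compound 3 (0.44 log units; beyond the scatter), concerns the fluorine on the aryl at the oxazole, not the ring on the piperazine. Compound 2 gives the highest number of the three, but it differs from compound 1 in two places at once, so only the two values themselves can be set side by side.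

Compound 4 `Cc1nc(-c2cccc(F)c2)c(C(=O)N2CCN(c3cccc(Cl)c3)CC2)o1` differs from compound 1 as follows: 3-chlorophenyl in place of 3,5-dimethoxyphenyl on an amine nitrogen in a ring. Among the compounds with values here, no measured step changes this ring alone, so no step bears directly on it. The comparison of compound 1 with compound 2 is the only hint that losing the 3,5-dimethoxyphenyl goes with a higher number in this assay. A moderate rise beyond the scatter is therefore expected for compound 4, as a 2.5-fold higher number from compound 1 to compound 4 (0.39 log units; beyond the scatter).

Compound 4 is estimated at 70 nM in this assay, with a range from 25 nM to 200 nM expected.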

Compound 4, half-maximal inhibitory concentration: 33.7 nM
Compound 4: the middle estimate sits 2.1-fold (0.32 log units) above what was measured; the measured number falls inside the stated range.
By their numbers in this assay, from the lowest: compound 3; then compounds 1 and 4 (each within the scatter of the next); then compound 2.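

In this assay, replacing the group on the amine nitrogen in the six-membered ring gives a 1.2-fold higher number from compound 1 to compound 4 (0.08 log units; within the scatter), with the 3-fluorophenyl held constant on the shared core. The entering 3-chlorophenyl has 7 heavy atoms and 0 hydrogen-bond acceptors, against 10 heavy atoms and 2 hydrogen-bond acceptors in the leaving 3,5-dimethoxyphenyl, so for this pair the number in this assay does not depend on the two oxygen atoms or on the larger group. No measurement on hand accounts for the two groups reading alike.

Going by these compounds alone, it remains open whether this equivalence holds with the 2-fluorophenyl of compound 3 on the shared core, since compound 1 and compound 4 are the only pair that isolates this change at the amine nitrogen. Also open, on these data alone, is how the position reads when the aryl group there gives way to a pyridine, or when the phenyl ring there carries a carboxylic acid or a nitrile in place of the chlorine.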